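Swapping the aryl group on a shared core: cytotoxicity unchanged

A few compounds are considered here, and "the series" means these few. Any claim that something is new, unique, unknown or untested is made for them only; others in the source may bear on it.

Compound 1 `O=C1CSC(c2ccc(F)cc2)N1CCN1CCCCC1` and compound 2 `O=C1CSC(c2ccccc2Cl)N1CCN1CCCCC1` share one core and differ only in the aryl group on a saturated ring carbon. In an ADME assay on Vero cells (Chlorocebus sabaeus) for cytotoxicity, read by neutral red uptake, tested at 12.3 ug/mL (a lower number here means a stronger effect, a higher number a weaker effect of the compound at the concentration tested), compound 1 gives 100%, and compound 2 gives 100%, so the step of no change at the digits printed from compound 1 to compound 2 (within the scatter) shows no change within the scatter. Among the compounds with values here, compound 2 therefore stands level with compound 1 on the numbers so far.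

Compound 3 `O=C1CSC(c2ccc(O)cc2)N1CCN1CCCCC1` has not yet been measured. It differs from compound 2 by 4-hydroxyphenyl in place of 2-chlorophenyl on a saturated ring carbon. Within the data shown here, the only measured step that bears on this is the one from compound 1 to compound 2, which also exchanged one aryl group at the same place and left this assay unchanged. On that basis the step of no change at the digits printed from compound 2 to compound 3 (within the scatter) is expected to be none beyond the scatter. Compound 3 is estimated at 100%, within a range from 88% to 105%.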

Compound 3, a percentage reported as activity, at one concentration (the size of the read-out at that concentration, not a potency): 100%
For compound 3 middle estimate and measured number coincide at the digits printed; measured number inside the range.
By their numbers in this assay, from the lowest: compounds 1, 2 and 3 (each within the scatter of the next).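

In this assay, 4-hydroxyphenyl in place of 2-chlorophenyl on the saturated ring carbon gives no change at the digits printed from compound 2 to compound 3 (within the scatter), and hydroxy in place of fluoro on an aromatic carbon gives no change at the digits printed from compound 1 to compound 3 (within the scatter). Within the data shown here, the earlier pair showed only that one halogen-bearing phenyl group could replace another, whereas this change brings in a group with 1 hydrogen-bond donor and 1 hydrogen-bond acceptor, where 2-chlorophenyl has neither, and the read-out stays level. No measurement here offers an explanation for this lack of change.

Going by these compounds, whether an amine or a carboxylic acid on the phenyl ring would also leave the read-out level remains open. So does the outcome of replacing the aryl group at this carbon with a longer chain.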